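The source may hold more compounds than are shown below. What is called first, only, known or untested is meant among the compounds shown, and "the series" means these compounds.

Measured compounds in a functional assay on the whole organism for inhibition, with Rattus norvegicus as the target, read by paw edema, with stated times of 1 h and 2 h, at a dose of 100 mg/kg by the oral route; on this read-out higher numbers stand for more inhibition at the one dose given (going by the name of the read-out) and lower numbers for less inhibition:
- compound 1 `O=C(O)c1ccc(NC(=O)[C@@H]2CC(O)CN2S(=O)(=O)c2ccc([N+](=O)[O-])cc2)cc1`: 52.3%
- compound 2 `Cc1ccccc1S(=O)(=O)N1CCC[C@H]1C(=O)Nc1ccc(C(=O)O)cc1`: 36.3%
- compound 3 `Cc1ccc(S(=O)(=O)N2CCC[C@H]2C(=O)Nc2ccc(C(=O)O)cc2)cc1`: 36.3%

Compound 3 stands level with compound 2; the two together are the lowest of the three numbers, and compound 1 lies higher by a margin beyond the scatter. Going by the values given here, the only single-place step measured is no change at the digits printed from compound 2 to compound 3 (within the scatter), which moves the methyl around the ring and does not touch the methyl-to-nitro exchange. Compound 4 `O=C(O)c1ccc(NC(=O)[C@@H]2CCCN2S(=O)(=O)c2ccc([N+](=O)[O-])cc2)cc1` differs from compound 3 by nitro in place of methyl on an aromatic carbon. Among the compounds with values here, compound 1 also carries a nitro on that ring and reads higher than compound 3, but it differs in a second place as well, so no single-place step covers the change. In this assay compound 4 is expected to move by a number 8.7 percentage points higher from compound 3 to compound 4 (within the scatter), toward the higher value of compound 1 but with wide uncertainty. Compound 4 is estimated at 45%, between 30% and 60%.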

Compound 4, a percentage reported as inhibition, in the whole organism at one dose (the size of the read-out at that dose, not a potency): 50.1%
Beside the measured number, compound 4's estimate is 5.1 percentage points below it; measured number inside the range.
By their numbers in this assay, from the lowest: compounds 2 and 3 (each within the scatter of the next); then compounds 4 and 1 (each within the scatter of the next).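

In this assay the 4-nitrophenyl group on the sulfonyl sulfur separates from both methylphenyl compounds: nitro in place of methyl at the same ring place gives a step beyond the scatter (a number 13.8 percentage points higher from compound 3 to compound 4 (beyond the scatter)), as does the exchange from 2-methylphenyl (a number 13.8 percentage points higher from compound 2 to compound 4 (beyond the scatter)). The hydroxy on the saturated ring carbon is not required for this level (a number 2.2 percentage points lower from compound 1 to compound 4 (within the scatter)). No measurement on hand explains the nitro step.

Going by these compounds, whether an amine or a nitrile at this ring place would read like nitro remains open. Also open, on these data alone, is how a carboxylic acid or a longer chain there would read.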